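Replacing piperidin-1-yl with methyl on the side chain

The compounds below may be only part of what the source reports. "The series", "measured", "known", "first", "only" and "open" are said of these compounds alone.

Of the compounds shown here, three with a shared core have been measured in a functional assay on U-87MG ATCC cells for cytotoxicity against U-87 MG (Homo sapiens), read by MTT assay, with a stated time of 72 h (a higher number here means a weaker inhibitor, a lower number a stronger inhibitor), so far. Compound 1 `COc1ncc(-c2ccc3nc(NC(=O)N(C)C)nn3c2)cc1NS(=O)(=O)c1ccc(F)cc1` gives 1780 nM in this test, compound 2 `COc1ncc(-c2ccc3nc(NC(=O)NCCN4CCCC4)nn3c2)cc1NS(=O)(=O)c1ccc(F)cc1` gives 1120 nM in the same test, and compound 3 `COc1ncc(-c2ccc3nc(NC(=O)NCCN4CCCCC4)nn3c2)cc1NS(=O)(=O)c1ccc(F)cc1` gives 1080 nM there. Compound 3 therefore stands level with the other two: a 1.0-fold lower number from compound 2 to compound 3 (0.02 log units; within the scatter) is one small step, and a 1.6-fold lower number from compound 1 to compound 3 (0.22 log units; within the scatter) is the other.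

Compound 4 `CCCNC(=O)Nc1nc2ccc(-c3cnc(OC)c(NS(=O)(=O)c4ccc(F)cc4)c3)cn2n1` has not been measured yet. It differs from compound 3 by one change methyl in place of piperidin-1-yl on a saturated chain carbon, two bonds along the chain from an amide-type nitrogen in which methyl takes the place of piperidin-1-yl on a saturated chain carbon, two bonds along the chain from an amide-type nitrogen. This turns 2-(piperidin-1-yl)ethyl into propyl. The closest evidence is a 1.0-fold lower number from compound 2 to compound 3 (0.02 log units; within the scatter) for a ring swap at that same place. A further guide is a 1.6-fold lower number from compound 1 to compound 2 (0.20 log units; within the scatter) for a change of the whole side chain. Within the data shown here, neither step leaves the scatter, and no measured compound carries propyl, so this remains an extrapolation. In this assay the expected step is a 1.3-fold higher number from compound 3 to compound 4 (0.11 log units; within the scatter) and no real shift is anticipated. Compound 4 is estimated at 1400 nM in a range from 650 nM to 3000 nM on repeated measurement.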

Compound 4, half-maximal inhibitory concentration: 420 nM
The estimate for compound 4 lay 3.3-fold (0.52 log units) above the measured number; measured number outside the range, below it.
By their numbers in this assay, from the lowest: compound 4; then compounds 3, 2 and 1 (each within the scatter of the next).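

In this assay, the earlier changes on this side chain all stayed within the scatter, so swapping one ring for another, or either ring-bearing chain for dimethylamino, gave no readable difference. Taking the ring away is the first change here that registers: methyl in place of piperidin-1-yl, on a saturated chain carbon two bonds along the chain from an amide-type nitrogen, gives a 2.6-fold lower number from compound 3 to compound 4 (0.41 log units; beyond the scatter) and the same replacement of pyrrolidin-1-yl gives a 2.7-fold lower number from compound 2 to compound 4 (0.43 log units; beyond the scatter), both modest but beyond the scatter. Propylamino also separates from dimethylamino on the carbonyl carbon, with a 4.2-fold lower number from compound 1 to compound 4 (0.63 log units; beyond the scatter), so the plain propyl chain stands apart from all three earlier side chains.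

No measurement available accounts for this lower number. Propyl differs from 2-(piperidin-1-yl)ethyl both in lacking the ring and in lacking the ring nitrogen, so the two remain tangled; a 2-cyclohexylethyl chain would keep the ring without that nitrogen, a 2-(diethylamino)ethyl chain would keep the nitrogen without the ring, and butyl or ethyl chains would show whether chain length matters.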